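Dithiocarbamate series: benzamide core with methyl-substituted nitrogen

The source may report more compounds than this note shows. Statements on the series, on what has been measured and on what is new or still open speak of the compounds shown alone.

Of the compounds shown here, two have been measured so far. Compound 1 `CN(C(=S)SCc1ccc(C(=O)Nc2ccccc2N)cc1)c1cccnc1` gives 46.1% in a functional assay on MGC-803 cells (Homo sapiens) for antiproliferative activity, read by CCK-8 assay, with a stated time of 72 h, tested at 2 uM; on this read-out higher numbers stand for a stronger effect at the one concentration tested and lower numbers for a weaker effect. Compound 2 `Nc1ccccc1NC(=O)c1ccc(CSC(=S)N2CCN(Cc3cccnc3)CC2)cc1` gives 37.7% in this assay. Of these two numbers, that of compound 1 has compound 2 within the usual scatter of it, so no ranking of the two is supported by the data; both carry the shared core and differ in the amine part of the thiocarbonyl.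

Compound 3 `CN(Cc1cccnc1)C(=S)SCc1ccc(C(=O)Nc2ccccc2N)cc1` has not yet been measured. It differs from compound 1 in one place: (pyridin-3-yl)methyl in place of pyridin-3-yl on an amide-type nitrogen. The amine part stays a methyl-bearing nitrogen on the thiocarbonyl carbon, and the pyridine ring is kept.

Among the measured compounds shown here, no measured pair in this set shows what such a change does, so the size of the step cannot be read from the numbers. Since the change is a single, small one and the two measured values sit within the scatter of each other, the expected step of a number 4.1 percentage points lower from compound 1 to compound 3 (within the scatter) is taken as none beyond the scatter, in either direction. Compound 3 is therefore estimated at 42%, with a range from 25% to 60%.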

Compound 3, a percentage reported as inhibition, at one concentration (the size of the read-out at that concentration, not a potency): 45.9%
Compound 3: the middle estimate sits 3.9 percentage points below what was measured; low and high end bracket the measured number.
By their numbers in this assay, from the lowest: compounds 2, 3 and 1 (each within the scatter of the next).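

Among the compounds shown here, replacing pyridin-3-yl with (pyridin-3-yl)methyl on the amide-type nitrogen gives the first single-place step. In this assay the step is a number 0.2 percentage points lower from compound 1 to compound 3 (within the scatter) and so separates compound 3 from compound 1 by no more than the usual scatter of this read-out. At this position, therefore, the pyridine ring can stand directly on the nitrogen or be carried by a methyl link with no distinction in inhibition at the one concentration tested, and nothing available on these compounds bears on the reason for this outcome.

Still open, as far as these compounds go, is whether a longer chain carrying the pyridine ring, a phenyl ring in place of the pyridine ring, or an ethyl group in place of the methyl on the same nitrogen would also stay within the scatter of compound 1. From the compounds shown here alone, since the read-out gives the size of the effect at a single concentration and not a potency, any difference in potency between compound 1 and compound 3 also remains open.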